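This account rests on a few compounds, and the source may have more. Where it says the series, first, only, none or still open, it means among the compounds named here.

Of the compounds shown here, three have so far been tested in a functional assay on HepG2 cells (Homo sapiens) for cytotoxicity, read by MTT assay, with a stated time of 48 h; a higher number here means a weaker inhibitor, a lower number a stronger inhibitor. Compound 1 `O=C(CSc1nc2ccc(NC(=O)c3ccc(Cl)cc3)cc2s1)NCc1ccc(Cl)cc1` gives 17800 nM in this assay. Compound 2 `CNC(=O)CSc1nc2ccc(NC(=O)c3ccc([N+](=O)[O-])cc3)cc2s1` carries a 4-nitrophenyl group on the carbonyl carbon and a methyl on the other amide nitrogen. For compound 2 this assay reports only a limit, > 100000 nM. Compound 3 `CNC(=O)CSc1nc2ccc(NC(C)=O)cc2s1` has a methyl in place of the 4-nitrophenyl on that carbonyl carbon. For compound 3 this assay again reports only a limit, > 100000 nM. The step that the two limits leave unreadable from compound 2 to compound 3 cannot be read because both of its ends sit at the limit of > 100000 nM in this assay, at which 2 of the 3 values shown sit. Compound 3 thus stands at the weak end of what is shown, with compound 1 the only one giving a number.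

Compound 4 `CNC(=O)CSc1nc2ccc(NC(=O)c3ccc(Cl)cc3)cc2s1` is the compound still to be measured. It differs from compound 3 in one place: 4-chlorophenyl in place of methyl on a carbonyl carbon. Among the measured compounds shown here, no measured step matches this change, and the one measured step at the same position, a step that the two limits leave unreadable from compound 2 to compound 3, is unreadable. Compound 1 holds the same 4-chlorophenyl group but a different group on the other amide nitrogen, so it offers only a hint. Compound 4 is therefore expected to remain a weak inhibitor, with an estimated at least 1.6-fold lower number from compound 3 to compound 4 (0.22 log units; that floor lies within the scatter) that may well leave it at the limit. The estimate for compound 4 is 60000 nM, within 20000 nM to 200000 nM.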

Compound 4, half-maximal inhibitory concentration: 15300 nM
Compound 4: middle estimate off by 3.9-fold (0.59 log units), on the high side; measured number below the stated range.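

In this assay, 4-chlorophenyl in place of methyl on a carbonyl carbon gives an at least 6.5-fold lower number from compound 3 to compound 4 (0.81 log units; beyond the scatter), so the group at this position can change the result, which the unreadable step between the two compounds at the limit could not show. The aromatic ring alone does not account for this, since chloro in place of nitro on an aromatic carbon gives an at least 6.5-fold lower number from compound 2 to compound 4 (0.81 log units; beyond the scatter). At the other amide nitrogen, hydrogen in place of 4-chlorophenyl on a saturated chain carbon bound to an amide-type nitrogen gives a 1.2-fold lower number from compound 1 to compound 4 (0.07 log units; within the scatter), so that change makes no readable difference with this group present.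

From the compounds shown here alone, both larger steps start from a limit, so their full size remains unknown: the limit of > 100000 nM in this assay, at which 2 of the 4 values shown sit. Also open is how an amine or a methoxy in place of the chloro on an aromatic carbon would behave.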